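Furan-to-thiophene swap on two dichlorobenzyl ether cores

This account rests on a few compounds, and the source may have more. Where it says the series, first, only, none or still open, it means among the compounds named here.

Measured compounds:
- compound 1 `Clc1ccc(COC(CCn2ccnc2)c2ccco2)c(Cl)c1`: 56200 nM
- compound 2 `Clc1ccc(Cl)c(COC(CCn2ccnc2)c2cccs2)c1`: 18000 nM
- compound 3 `Clc1ccc(Cl)c(COC(CCn2ccnc2)c2ccco2)c1`: 37600 nM

All three were run in an ADME assay on J774.A1 cells (Mus musculus) for cytotoxicity, read by MTT assay, with a stated time of 72 h; on this read-out higher numbers stand for lower toxicity in this test and lower numbers for higher toxicity in this test. Compound 1 stands highest of the three numbers in this assay; its gap to compound 3 is within the scatter, its gap to compound 2 beyond it. Compound 1 and compound 3 share the same atoms joined differently; the difference between the two cores is not broken down here.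

Within the core of compound 3, one change is measured: thiophen-2-yl in place of furan-2-yl on a saturated chain carbon bound to an oxygen on a saturated carbon and a saturated chain carbon. It gave a 2.1-fold lower number from compound 3 to compound 2 (0.32 log units; beyond the scatter) in this assay.

Compound 4 `Clc1ccc(COC(CCn2ccnc2)c2cccs2)c(Cl)c1` is not yet measured. It arises from compound 1 by the same change, (thiophen-2-yl in place of furan-2-yl on a saturated chain carbon bound to an oxygen on a saturated carbon and a saturated chain carbon), at the same place. The expectation rests on one example, so it is taken over as measured: the step from compound 1 to compound 4 is estimated at a 2.1-fold lower number from compound 1 to compound 4 (0.32 log units; beyond the scatter), set beside a 2.1-fold lower number from compound 3 to compound 2 (0.32 log units; beyond the scatter). On that basis compound 4 is expected at 27000 nM, with a range of 12000 nM to 56000 nM in this assay.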

Compound 4, half-maximal cytotoxic concentration: 29700 nM
The estimate for compound 4 lay 1.1-fold (0.04 log units) below the measured number; measured number inside the range.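

On the core of compound 1, thiophen-2-yl in place of furan-2-yl gives a 1.9-fold lower number from compound 1 to compound 4 (0.28 log units; within the scatter) in this assay. Set beside the earlier step, the size of the change carries over between the two cores in this assay: the same change on two cores in this assay, a 2.1-fold lower number (0.32 log units; beyond the scatter) from compound 3 to compound 2 and a 1.9-fold lower number (0.28 log units; within the scatter) from compound 1 to compound 4, 1.1-fold (0.04 log units) apart, within the scatter of two such steps

This agreement rests on two matched pairs in one assay, and the step on the core of compound 1 lies within the scatter when read alone; it supports carrying the change between these two closely related cores, but it gives no rule for other cores and no reason for the size of either step.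

The compounds shown leave open how a phenyl ring or a carboxylic acid would read at the same place, on a saturated chain carbon bound to an oxygen on a saturated carbon and a saturated chain carbon. Also open, on these data alone, is whether the furan-2-yl to thiophen-2-yl step would keep its size on a core with an amine in place of the ether oxygen.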